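This account rests on a few compounds, and the source may have more. Where it says the series, first, only, none or still open, it means among the compounds named here.

Measured so far in a functional assay on MDA-MB-231 cells (Homo sapiens) for antiproliferative activity, with a stated time of 4 days; a higher number here means a weaker inhibitor, a lower number a stronger inhibitor:
- compound 1 `COc1ccc(-c2[nH]c3ccc(OC)cc3c2C=C(C#N)C#N)cc1`: 590 nM
- compound 2 `COc1ccc(-c2[nH]c3ccc(F)cc3c2C=C(C#N)C#N)cc1`: 400 nM
- compound 3 `CCCc1ccc2[nH]c(-c3ccc(OC)cc3)c(C=C(C#N)C#N)c2c1`: 83 nM

Compound 3 gives the lowest number of the three, and both of its steps lie beyond the scatter: a 7.1-fold lower number from compound 1 to compound 3 (0.85 log units; beyond the scatter) and a 4.8-fold lower number from compound 2 to compound 3 (0.68 log units; beyond the scatter). The remaining step, a 1.5-fold lower number from compound 1 to compound 2 (0.17 log units; within the scatter), lies within the scatter.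

Next in the series is compound 4 `COc1ccc(-c2[nH]c3ccc(C(C)C)cc3c2C=C(C#N)C#N)cc1`, which carries isopropyl in place of propyl on an aromatic carbon. The two measured steps to compound 3 bear on this change only indirectly, since each replaces a different kind of group with propyl, and both are modest. For the measured compounds named here, no measured pair compares propyl with isopropyl. The working expectation is therefore that compound 4 stays close to compound 3, which gives 83 nM, with a slightly higher number the more likely direction. The expected step is a 1.2-fold higher number from compound 3 to compound 4 (0.08 log units; within the scatter), and no change beyond the scatter is expected. In this assay the estimated value for compound 4 is 100 nM, with an expected range from 40 nM to 250 nM.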

Compound 4, half-maximal inhibitory concentration: 210 nM
The estimate for compound 4 lay 2.1-fold (0.32 log units) below the measured number; the range from low to high includes it.
By their numbers in this assay, from the lowest: compound 3; then compounds 4, 2 and 1 (each within the scatter of the next, the first and the last beyond it).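

In this assay this position distinguishes between two chains of the same size: a 2.5-fold higher number from compound 3 to compound 4 (0.40 log units; beyond the scatter) when the chain is isopropyl, so the lower number seen with propyl does not extend to every three-carbon chain here. Isopropyl keeps only part of the advantage over the earlier groups, giving a 2.8-fold lower number from compound 1 to compound 4 (0.45 log units; beyond the scatter) while a 1.9-fold lower number from compound 2 to compound 4 (0.28 log units; within the scatter), so compound 4 is separated from the methoxy compound but not from the fluoro compound. Nothing available explains the difference between propyl and isopropyl.

From the compounds shown here alone, whether a longer chain such as butyl would follow propyl or isopropyl remains open. Also open, going by these compounds, is how an amine or a carboxylic acid would behave at this position on the shared core.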